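This account rests on a few compounds, and the source may have more. Where it says the series, first, only, none or still open, it means among the compounds named here.

Compound 1 `COc1cc(C2=NN(C(C)=O)C(c3c(Cl)cccc3Cl)O2)cc(OC)c1OC` gives -2.2% in a functional assay on PC-3 cells (Homo sapiens) for antiproliferative activity, read by MTT assay, tested at 5 uM; on this read-out higher numbers stand for a stronger effect at the one concentration tested and lower numbers for a weaker effect. Compound 2 `COc1cc(C2=NN(C(C)=O)C(c3cc(OC)c(OC)c(OC)c3)O2)cc(OC)c1OC` gives 0.1% in this assay; the two numbers lie within the usual scatter of each other, so compound 1 stands together with compound 2 at no measurable effect at the concentration tested. Compound 3 `COc1cc(C2=NN(C(C)=O)C(c3cccc(C(F)(F)F)c3)O2)cc(OC)c1OC` differs from compound 1 in one place: 3-(trifluoromethyl)phenyl in place of 2,6-dichlorophenyl on a saturated ring carbon. Among the compounds with values here, no step between measured compounds covers this change, and both measured compounds show no effect, so no step beyond the scatter is expected in this assay; the expected step is a number 4.2 percentage points higher from compound 1 to compound 3 (within the scatter). Compound 3 is expected to give 2%, within a range from -12% to 18%.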

Compound 3, a percentage reported as inhibition, at one concentration (the size of the read-out at that concentration, not a potency): 43.6%
The estimate for compound 3 lay 41.6 percentage points below the measured number; measured number outside the range, above it.
By their numbers in this assay, from the lowest: compounds 1 and 2 (each within the scatter of the next); then compound 3.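

In this assay, the aryl group on the saturated ring carbon is not a silent position: 3-(trifluoromethyl)phenyl in place of 2,6-dichlorophenyl gives a number 45.8 percentage points higher from compound 1 to compound 3 (beyond the scatter) at the one concentration tested. Compound 1 and compound 2 alone gave no sign that this position could move the read-out. Nothing measured here accounts for the step.

Still open, on these data alone, is whether the gain follows the trifluoromethyl group itself or would persist with a nitrile or an amine in its place. The compounds shown also give no potency, only the effect at one concentration.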